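Swapping the Aryl Ring on Compound 1

The source may report more compounds than this note shows. Statements on the series, on what has been measured and on what is new or still open speak of the compounds shown alone.

Among the measured compounds shown here, compound 1 `Cc1cnc(Nc2ccnn2C)nc1-c1cc2n(c1)C(=O)N([C@H](CO)c1ccc(Cl)c(F)c1)C2` gives 92.2 nM in a functional assay on COLO 205 cells (Homo sapiens) for antiproliferative activity, read by luminescence, with a stated time of 72 h (on this read-out lower numbers stand for stronger inhibition and higher numbers for weaker inhibition), the lower of the two numbers measured so far. Compound 2 `Cc1cnc(Nc2ccnn2C)nc1-c1cc2n(c1)C(=O)N(Cc1ccc(F)c(F)c1)C2` gives 293 nM in this assay, and the step of a 3.2-fold higher number from compound 1 to compound 2 (0.50 log units; beyond the scatter) shows what is lost when the whole 1-(4-chloro-3-fluorophenyl)-2-hydroxyethyl group is replaced by a 3,4-difluorobenzyl group. Compound 3 `COc1cc(F)cc([C@@H](CO)N2Cc3cc(-c4nc(Nc5ccnn5C)ncc4C)cn3C2=O)c1` keeps that chain and alters only the aromatic ring attached to it: 3-fluoro-5-methoxyphenyl in place of 4-chloro-3-fluorophenyl on a saturated chain carbon bound to an amide-type nitrogen in a ring and a saturated chain carbon. For the measured compounds named here, no measured step changes this ring alone, and the single measured step alters the ring and the chain together, which makes it a loose guide for compound 3. With the chain retained, a shift smaller than that step is expected, with the number more likely to rise than to fall. Compound 3 is estimated at 150 nM, within 50 nM to 450 nM, a step of a 1.6-fold higher number from compound 1 to compound 3 (0.21 log units; within the scatter) expected to stay near the scatter.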

Compound 3, half-maximal inhibitory concentration: 89.6 nM
Estimate against measurement, compound 3: 1.7-fold (0.22 log units) above; low and high end bracket the measured number.
By their numbers in this assay, from the lowest: compounds 3 and 1 (each within the scatter of the next); then compound 2.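

In this assay, the step of a 1.0-fold lower number from compound 1 to compound 3 (0.01 log units; within the scatter) shows that, with the 2-hydroxyethyl chain kept, 3-fluoro-5-methoxyphenyl can take the place of 4-chloro-3-fluorophenyl on this saturated chain carbon without moving the number beyond the scatter, even though chlorine leaves and a methoxy group enters. The earlier step of a 3.2-fold higher number from compound 1 to compound 2 (0.50 log units; beyond the scatter) altered the ring and the chain together, whereas this pair isolates the aromatic ring. No measurement here explains why these two rings give such similar numbers.

The compounds shown leave open whether the hydroxymethyl part of the chain accounts for the gap between compound 1 and compound 2. As far as these compounds go, it also remains open whether this position would tolerate a more different group, such as a ring bearing an amine or a carboxylic acid.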